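Methoxy to methoxymethyl on an amidine: compound 3 to compound 4

This account rests on a few compounds, and the source may have more. Where it says the series, first, only, none or still open, it means among the compounds named here.

Measured so far:
compound 1 `COCCNC(=N)NCCC(C)C`: 4%
compound 2 `C=CCCNC(=N)NCCCCN`: 23%
compound 3 `COCC(=N)NCCCCN`: 42%

In an assay on isolated protein for inhibition of Nitric oxide synthase, inducible (Homo sapiens), read by spectrophotometry, using NADPH, tested at 1 mM, in the presence of a further agent that is not named here (a higher number here means more inhibition at the concentration tested (going by the name of the read-out), a lower number less inhibition), compound 3 gives 42%, the highest of the three numbers. Compound 2 sits lower by a margin beyond the scatter, and compound 1 lower still, also beyond the scatter. Compound 4 `COCCC(=N)NCCCCN` differs from compound 3 in one place: methoxymethyl in place of methoxy on a saturated chain carbon bound to a carbon with a double bond to nitrogen. For the measured compounds named here, no pair of measured compounds isolates this kind of change, so its size cannot be read from the numbers at hand. The chain-extended group is expected to cost a little or nothing beyond the scatter, so a small downward step a number 7 percentage points lower from compound 3 to compound 4 (within the scatter) is estimated. Compound 4 is expected to give about 35%, within a range from 15% to 55%.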

Compound 4, a percentage reported as inhibition, at one concentration (the size of the read-out at that concentration, not a potency): 16%
Beside the measured number, compound 4's estimate is 19 percentage points above it, and the stated range covers the measured number.
By their numbers in this assay, from the lowest: compound 1; then compounds 4 and 2 (each within the scatter of the next); then compound 3.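

In this assay, methoxymethyl in place of methoxy on a saturated chain carbon bound to a carbon with a double bond to nitrogen gives a number 26 percentage points lower from compound 3 to compound 4 (beyond the scatter). For the compounds shown here, this is the first single-place comparison, and it shows that this position is sensitive to the change, though it remains a single pair. Nothing at hand bears on why the number falls.

On these data alone, it remains open whether a hydroxymethyl group or a plain ethyl chain at this place would keep the number of compound 3 (42%). A longer ether chain is equally unresolved.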